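A few compounds are considered here, and "the series" means these few. Any claim that something is new, unique, unknown or untested is made for them only; others in the source may bear on it.

In a functional assay on KYSE-70 cells for antiproliferative activity against KYSE-70 cell line (Homo sapiens), read by MTT assay, with a stated time of 72 h (on this read-out higher numbers stand for weaker inhibition and lower numbers for stronger inhibition), compound 1 `O=C(Nc1ccc(Cl)cc1)c1cc(=O)[nH]c2cc(Br)ccc12` gives > 20000 nM, which is a limit and not a number. Compound 2 `O=C(Nc1ccc(F)cc1F)c1cc(=O)[nH]c2cc(Br)ccc12` gives > 20000 nM, likewise a limit. Compound 3 `O=C(Nc1ccccn1)c1cc(=O)[nH]c2cc(Br)ccc12` gives 11000 nM. Among the measured compounds shown here, the one measured step, an at least 1.8-fold lower number from compound 1 to compound 3 (0.25 log units; that floor lies within the scatter), puts pyridin-2-yl in place of 4-chlorophenyl on an amide-type nitrogen, and its floor lies within the scatter. Compound 4 `CC(C)(C)c1ccc(NC(=O)c2cc(=O)[nH]c3cc(Br)ccc23)cc1` carries a different change: tert-butyl in place of chloro on an aromatic carbon. For the measured compounds named here, no measured step covers this swap, and the nearest guide is the limit of > 20000 nM in this assay, at which 2 of the 3 values shown sit, with compound 3 as the exception. No step beyond the scatter is therefore expected in this assay, and the expected step is a number no higher from compound 1 to compound 4 (the limit leaves the size open). For compound 4 the estimate is 20000 nM, with an expected range of 9000 nM to 40000 nM.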

Compound 4, half-maximal inhibitory concentration: > 20000 nM
Compound 4: only a limit was reported; the forecaster's own chance of this, stated with the estimate: 65%; the middle value sits exactly at the limit.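

Compound 1 and compound 4 both stand only as limits in this assay, and the step between them cannot be read. Whether tert-butyl in place of chloro changes the read-out at all stays open, as most values shown sit at one limit: the limit of > 20000 nM in this assay, at which 3 of the 4 values shown sit.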